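Dichlorophenyl in Place of Methoxyphenyl: A Solubility Forecast

This account rests on a few compounds, and the source may have more. Where it says the series, first, only, none or still open, it means among the compounds named here.

Three compounds sharing one core have been examined in a physicochemical assay for solubility, in phosphate buffer, at pH 7.4; on this read-out lower numbers stand for lower solubility and higher numbers for higher solubility. Compound 1 `CCOC(=O)c1c(-c2ccc(OC)cc2)[nH]c2cccc(OC)c2c1=O` reaches only a limit of the assay, > 100000 nM. Compound 3 `CCOC(=O)c1c(-c2cccc(C(F)(F)F)c2)[nH]c2cccc(OC)c2c1=O` likewise stops at a limit, > 100000 nM. For the measured compounds named here, compound 2 `CCOC(=O)c1c(-c2ccc(OC)cc2)[nH]c2cc(OC)ccc2c1=O`, in this assay, gives 8000 nM, which is the only number among the three; the other two results sit at the limit of > 100000 nM in this assay, at which 2 of the 3 values shown sit. Going by the values given here, no two of the three compounds differ in a single place, so the data show no measured step between them.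

Compound 4 `CCOC(=O)c1c(-c2ccc(Cl)c(Cl)c2)[nH]c2cc(OC)ccc2c1=O` has not yet been measured in this assay. It differs from compound 2 in one place: 3,4-dichlorophenyl in place of 4-methoxyphenyl on an aromatic carbon. Among the compounds with values here, because no step between measured compounds is available, the expectation rests only on this change and on the number for compound 2. Compound 4 is expected to show lower solubility than compound 2, with the step from compound 2 to compound 4 estimated as a 4.0-fold lower number from compound 2 to compound 4 (0.60 log units; beyond the scatter). The estimate for compound 4 in this assay is 2000 nM, with a range from 400 nM to 10000 nM.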

Compound 4, solubility: 17000 nM
Estimate against measurement, compound 4: 8.5-fold (0.93 log units) below, outside the stated range (above it).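

This position, on an aromatic carbon next to the ring nitrogen, now has its first readable step: in this assay, 3,4-dichlorophenyl in place of 4-methoxyphenyl gives a 2.1-fold higher number from compound 2 to compound 4 (0.33 log units; beyond the scatter). The two groups have the same count of heavy atoms, while the entering group has no hydrogen-bond acceptor and the leaving group has one, so losing that acceptor did not bring the number down on this core. Compound 1 and compound 3 each stop at a limit of the assay, and steps involving them cannot be read: the limit of > 100000 nM in this assay, at which 2 of the 4 values shown sit.

From the compounds shown here alone, whether the same change gives a similar step on the core of compound 1 stays open. So does the reading of an amine or a carboxylic acid on the phenyl ring at this position.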